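The compounds below may be only part of what the source reports. "The series", "measured", "known", "first", "only" and "open" are said of these compounds alone.

Measured so far:
Compound 1 `CCCCOc1ccc(C(=O)/C=C/c2c(/C=C/c3ccc(OC)cc3)cc(OC)cc2OC)cc1` gives 8.7 ug/mL in a functional assay on A549 cells (Homo sapiens) for antiproliferative activity, read by MTT assay, with a stated time of 48 h; on this read-out lower numbers stand for stronger inhibition and higher numbers for weaker inhibition.
Compound 2 `COc1ccc(/C=C/c2cc(OC)cc(OC)c2/C=C/C(=O)c2cccc(Br)c2)cc1` gives 8.1 ug/mL in this assay.
Compound 3 `COc1ccc(/C=C/c2cc(OC)cc(OC)c2/C=C/C(=O)c2ccc(OC)cc2)cc1` gives 4.5 ug/mL in this assay.

On these three numbers compound 1 carries the highest value, with compound 2 nearest to it and compound 3 furthest away, both separations lying within the scatter. Compound 4 `COc1ccc(/C=C/c2cc(OC)cc(OC)c2/C=C/C(=O)c2ccc(C)c(C)c2)cc1` has not yet been measured in this assay. Relative to compound 1 the change is 3,4-dimethylphenyl in place of 4-butoxyphenyl on a carbonyl carbon.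

Within the data shown here, two measured steps touch the same place, the aryl group on the carbonyl carbon: a 1.1-fold lower number from compound 1 to compound 2 (0.03 log units; within the scatter) and a 1.8-fold lower number from compound 2 to compound 3 (0.26 log units; within the scatter). The third step, a 1.9-fold lower number from compound 1 to compound 3 (0.29 log units; within the scatter), also stays within the scatter. Among the measured compounds shown here, none of the measured changes at this position has moved the number beyond the usual spread of repeats, and nothing addresses a 3,4-dimethylphenyl group directly. The expectation for compound 4 in this assay is therefore a step of a 1.3-fold lower number from compound 1 to compound 4 (0.13 log units; within the scatter), essentially no movement beyond the scatter, with a slight lean toward the lower side because the two aryl swaps gave a 1.1-fold lower number from compound 1 to compound 2 (0.03 log units; within the scatter) and a 1.8-fold lower number from compound 2 to compound 3 (0.26 log units; within the scatter).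

Compound 4 is estimated at 6.5 ug/mL, expected to fall between 3 ug/mL and 14 ug/mL.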

Compound 4, half-maximal inhibitory concentration: 0.1 ug/mL
Estimate against measurement, compound 4: 65-fold (1.81 log units) above; measured number below the stated range.
By their numbers in this assay, from the lowest: compound 4; then compounds 3, 2 and 1 (each within the scatter of the next).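

In this assay the aryl group on the carbonyl carbon now proves able to move the number far beyond the scatter in a single swap: 3,4-dimethylphenyl gives an 87-fold lower number from compound 1 to compound 4 (1.94 log units; beyond the scatter) against 4-butoxyphenyl, an 81-fold lower number from compound 2 to compound 4 (1.91 log units; beyond the scatter) against 3-bromophenyl and a 45-fold lower number from compound 3 to compound 4 (1.65 log units; beyond the scatter) against 4-methoxyphenyl on the same core. The earlier steps shown here at this place stayed within the scatter, so 4-butoxyphenyl, 3-bromophenyl and 4-methoxyphenyl gave no sign of this sensitivity, and compound 4 alone stands apart from them. The swap from compound 1 also removes the ether oxygen, yet compound 2 has no such oxygen on this aryl group and stays within the scatter of compound 1, so the loss of that oxygen does not by itself separate compound 4 from the others.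

Going by these compounds, whether both methyl groups are needed remains open, and 3-methylphenyl, 4-methylphenyl and 3,4-dichlorophenyl would each test a part of that question. Nothing given here explains the size of the step.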